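This account rests on a few compounds, and the source may have more. Where it says the series, first, only, none or still open, it means among the compounds named here.

In an assay on isolated protein for inhibition of RAC-alpha serine/threonine-protein kinase (Homo sapiens) (on this read-out lower numbers stand for stronger inhibition and higher numbers for weaker inhibition), compound 1, `COC(=O)c1cc2c(Nc3ccccc3)[nH]nc2s1`, gives 16000 nM. Among the measured compounds shown here, compound 2, `Cc1n[nH]c2sc(C(N)=O)cc12`, is known in this assay only as a limit, > 20000 nM, and it is the one value of the two that sits at the limit of > 20000 nM in this assay, at which 1 of the 2 values shown sits. Compound 3, `CCCCNC(=O)c1cc2c(C)n[nH]c2s1`, carries butyl in place of hydrogen on an amide-type nitrogen, butyl in place of hydrogen on an amide-type nitrogen. For the measured compounds named here, no measured pair matches that change, so the size of the step is uncertain; a shift of no more than the usual scatter, in either direction, is expected, as an at least 1.3-fold lower number from compound 2 to compound 3 (0.12 log units; that floor lies within the scatter). Compound 3 is estimated at 15000 nM, within 4000 nM to 50000 nM.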

Compound 3, half-maximal inhibitory concentration: > 20000 nM
Compound 3 gave a limit, no number; the forecaster's own chance of this, stated with the estimate: 50%; middle value at least 1.3-fold (0.12 log units) from the limit.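

Compound 2 and compound 3 are both known only as limits, so no step can be read between them: the limit of > 20000 nM in this assay, at which 2 of the 3 values shown sit. The compounds shown leave open whether butyl in place of hydrogen on an amide-type nitrogen changes inhibition at all, and in which direction.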